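A Second Ring on the Sulfonyl Arm: What to Expect

The source may report more compounds than this note shows. Statements on the series, on what has been measured and on what is new or still open speak of the compounds shown alone.

Compound 1 `COc1cc2nc(N3CCN(S(=O)(=O)c4ccccc4[N+](=O)[O-])CC3)nc(N)c2cc1OC` gives 35000 nM in a functional assay on PC-3 cells (Homo sapiens) for inhibition; a lower number here means a stronger inhibitor, a higher number a weaker inhibitor.
Compound 2 `COc1cc2nc(N3CCN(S(=O)(=O)c4ccc(C(F)(F)F)cc4)CC3)nc(N)c2cc1OC` gives 27000 nM in this assay.
Compound 3 `COc1cc2nc(N3CCN(S(=O)(=O)c4cccc(C(=O)O)c4)CC3)nc(N)c2cc1OC` gives 53000 nM in this assay.

All three compounds share the same core and differ only in the aryl group attached to the sulfonyl sulfur. Compound 2 carries the lowest of the three numbers, yet it cannot be called the strongest: the steps of a 1.3-fold lower number from compound 1 to compound 2 (0.11 log units; within the scatter) and a 2.0-fold higher number from compound 2 to compound 3 (0.29 log units; within the scatter) both lie within the scatter, as does a 1.5-fold higher number from compound 1 to compound 3 (0.18 log units; within the scatter). Taken together, these three steps show that exchanging one aryl group for another at this position has not moved the number beyond the scatter.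

Compound 4 `COc1cc2nc(N3CCN(S(=O)(=O)c4ccc(-c5ccc(C)cc5)cc4)CC3)nc(N)c2cc1OC` is the next step from compound 2: 4-methylphenyl in place of trifluoromethyl on an aromatic carbon. For the measured compounds named here, no measured step adds a second aromatic ring, so the only guidance is that every change made so far at this position stayed within the scatter. The expected step is therefore small, a 1.1-fold lower number from compound 2 to compound 4 (0.03 log units; within the scatter), with no direction claimed beyond the scatter. For compound 4 the estimated value is 25000 nM, expected to fall between 8000 nM and 80000 nM.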

Compound 4, half-maximal inhibitory concentration: 3400 nM
The estimate for compound 4 lay 7.4-fold (0.87 log units) above the measured number; the whole stated range lies above it.
By their numbers in this assay, from the lowest: compound 4; then compounds 2, 1 and 3 (each within the scatter of the next).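

For the compounds shown here, putting 4-methylphenyl in place of trifluoromethyl gives a 7.9-fold lower number from compound 2 to compound 4 (0.90 log units; beyond the scatter) in this assay, the first step at this position to lie beyond the scatter. The aryl group on the sulfonyl sulfur can therefore move the number after all, even though swapping one singly ringed aryl group for another among compounds 1, 2 and 3 did not. What enters here is larger than what leaves, with a second six-membered aromatic ring in place of a group with no ring, but no measurement shown here explains the lower number.

On these data alone, compound 4 adds the second ring and its methyl together, so their separate shares in the step remain open. An unsubstituted phenyl ring would address this, and an amine or a longer chain in place of the methyl would show how much the end of the second ring can tolerate.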